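This account rests on a few compounds, and the source may have more. Where it says the series, first, only, none or still open, it means among the compounds named here.

Compound 3 `CCCc1nnsc1CO/N=C/c1c(C)nn(C)c1Oc1ccccc1Cl` is one of three measured members of the series; in a functional assay on Huh-7 cells (Homo sapiens) for inhibition, read by MTT assay, with a stated time of 48 h (a higher number here means a weaker inhibitor, a lower number a stronger inhibitor), compound 3 gives only the limit > 50000 nM. Compound 1 `Cc1nnsc1CO/N=C/c1c(C)nn(C)c1Oc1ccccc1Cl` in this assay gives the limit > 50000 nM. Compound 2 `Cc1nnsc1CO/N=C/c1c(C)nn(C)c1Oc1ccc(F)cc1` likewise gives the limit > 50000 nM. Compound 3 thus stands at the limit, with no number to place it against the others. Compound 4 `CCCc1nnsc1CO/N=C/c1c(C)nn(C)c1Oc1ccc(F)cc1` differs from compound 3 in one place: 4-fluorophenyl in place of 2-chlorophenyl on an oxygen on an aromatic ring. The same exchange occurs from compound 1 to compound 2, where a step that the two limits leave unreadable from compound 1 to compound 2; the other measured step, a step that the two limits leave unreadable from compound 1 to compound 3, is equally unreadable, since (the limit of > 50000 nM in this assay, at which 3 of the 3 values shown sit). Among the compounds with values here, no step of readable size is therefore expected in this assay, a step that the limit leaves unreadable from compound 3 to compound 4. Compound 4 is expected to give 80000 nM, within 30000 nM to 300000 nM, most likely reported again only as a limit.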

Compound 4, half-maximal inhibitory concentration: > 50000 nM
Compound 4: no number, only a limit; the forecaster's own chance of this, stated with the estimate: 90%; the middle value does not contradict the limit.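

No step from compound 2 or compound 3 to compound 4 can be read in this assay, because each value is only a limit: the limit of > 50000 nM in this assay, at which 4 of the 4 values shown sit.

The compounds shown leave open the size of both exchanges, and whether any compound in the series gives a number rather than a limit.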